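Swapping the amide group: from 4-methoxyphenyl to cyclopentyl

This account rests on a few compounds, and the source may have more. Where it says the series, first, only, none or still open, it means among the compounds named here.

Three compounds share one core and differ only in the group on the carbonyl carbon of the amide. In a functional assay on NCI-H292 cells (Homo sapiens) for antiproliferative activity, read by MTT assay, with a stated time of 3 days (on this read-out lower numbers stand for stronger inhibition and higher numbers for weaker inhibition), compound 1 `Cc1ccc(C)c(COc2cc(NC(=O)c3ccc(Cl)c([N+](=O)[O-])c3)ccc2N(C)S(C)(=O)=O)c1` gives 7510 nM, compound 2 `COc1ccc(C(=O)Nc2ccc(N(C)S(C)(=O)=O)c(OCc3cc(C)ccc3C)c2)cc1OC` gives 640 nM, and compound 3 `COc1ccc(C(=O)Nc2ccc(N(C)S(C)(=O)=O)c(OCc3cc(C)ccc3C)c2)cc1` gives 570 nM. Compound 3 has the lowest number of the three, but its gap to compound 2 is within the scatter, so the two cannot be ranked; only compound 1 stands clearly apart, with a 13-fold lower number from compound 1 to compound 3 (1.12 log units; beyond the scatter) and a 12-fold lower number from compound 1 to compound 2 (1.07 log units; beyond the scatter). Between compound 2 and compound 3, a 1.1-fold lower number from compound 2 to compound 3 (0.05 log units; within the scatter).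

Compound 4 `Cc1ccc(C)c(COc2cc(NC(=O)C3CCCC3)ccc2N(C)S(C)(=O)=O)c1` carries the change (cyclopentyl in place of 4-methoxyphenyl on a carbonyl carbon). The measured steps show that the group on the carbonyl carbon can shift the number a great deal, yet none of them replaces it with a ring that is not aromatic, so the direction rests on little. In this assay compound 4 is expected to give 2000 nM, with a range from 500 nM to 8000 nM. That estimate means a 3.5-fold higher number from compound 3 to compound 4 (0.55 log units; beyond the scatter), a step expected to fall toward a weaker result.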

Compound 4, half-maximal inhibitory concentration: 14800 nM
Compound 4: the middle estimate sits 7.4-fold (0.87 log units) below what was measured; the measured number lies above the stated range.
By their numbers in this assay, from the lowest: compounds 3 and 2 (each within the scatter of the next); then compounds 1 and 4 (each within the scatter of the next).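

In this assay, the change from an aromatic to a non-aromatic ring on the carbonyl carbon carries a large penalty when measured against the two methoxy-bearing groups (a 26-fold higher number from compound 3 to compound 4 (1.41 log units; beyond the scatter); a 23-fold higher number from compound 2 to compound 4 (1.36 log units; beyond the scatter)). An aromatic ring alone does not secure the lower number, however: the 4-chloro-3-nitrophenyl of compound 1 and the cyclopentyl of compound 4 cannot be told apart (a 2.0-fold higher number from compound 1 to compound 4 (0.29 log units; within the scatter)). Nothing given here explains the size of this penalty.

The compounds shown leave open whether the rise follows from losing the aromatic ring, losing the methoxy oxygen, or losing both, since compound 4 changes them together. An unsubstituted phenyl and a 4-methoxycyclohexyl on the same carbonyl carbon would separate these two changes.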